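A few compounds are considered here, and "the series" means these few. Any claim that something is new, unique, unknown or untested is made for them only; others in the source may bear on it.

Measured in a functional assay on MIA PaCa-2 cells (Homo sapiens) for inhibition, read by MTT assay, with a stated time of 72 h; on this read-out lower numbers stand for stronger inhibition and higher numbers for weaker inhibition:
- Compound 1 (`COc1cc(NC(C)CCCNC(=O)Nc2ccc(Br)cc2)c2ncccc2c1`) gives 23000 nM
- Compound 2 (`COc1cc(NC(C)CCCNC(=O)NNC(=O)Nc2ccc(O)cc2)c2ncccc2c1`) gives 142000 nM

Compound 2 has the higher of the two numbers, so it is the weaker inhibitor here. Compound 3 (`COc1cc(NC(C)CCCNC(=O)Nc2ccc(O)cc2)c2ncccc2c1`) is still unmeasured. It differs from compound 2 by one change, (4-hydroxyphenyl in place of ((4-hydroxyphenyl)carbamoyl)amino on an amide-type nitrogen), in words 4-hydroxyphenyl in place of ((4-hydroxyphenyl)carbamoyl)amino on an amide-type nitrogen. Among the compounds with values here, the only measured step, a 6.2-fold higher number from compound 1 to compound 2 (0.79 log units; beyond the scatter), introduced that longer group in place of 4-bromophenyl. Removing part of it should undo part of that step, although no measurement isolates 4-bromophenyl against 4-hydroxyphenyl. The expected step is a 2.8-fold lower number from compound 2 to compound 3 (0.45 log units; beyond the scatter), towards a lower number. For compound 3 the estimate is 50000 nM, with an expected range from 18000 nM to 130000 nM, which is still a rough guess.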

Compound 3, half-maximal inhibitory concentration: 57000 nM
The estimate for compound 3 lay 1.1-fold (0.06 log units) below the measured number; the range from low to high includes it.
By their numbers in this assay, from the lowest: compound 1; then compound 3; then compound 2.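

In this assay, the shorter 4-hydroxyphenyl on the amide-type nitrogen gives a 2.5-fold lower number from compound 2 to compound 3 (0.40 log units; beyond the scatter) and so recovers part of the earlier loss. Hydroxy in place of bromo on an aromatic carbon can now be read alone, and it gives a 2.5-fold higher number from compound 1 to compound 3 (0.39 log units; beyond the scatter) as a change of its own, one that the first pair mixed with the longer group. No available evidence explains either step.

From the compounds shown here alone, whether an amine or a carboxylic acid on that aromatic carbon would give a lower number than compound 1 stays open. Going by these compounds, the effect of a longer chain on the amide-type nitrogen also stays open.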